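Methylphenyl swap in the series: expectation for compound 4

The source may report more compounds than this note shows. Statements on the series, on what has been measured and on what is new or still open speak of the compounds shown alone.

Compound 3 (`Cc1cccc(-c2cc(C)c(Oc3cc(N)nc(Nc4ccc(C#N)cc4)n3)c(C)c2)c1`) gives 27600 nM in a toxicity assay on MT4 cells (Homo sapiens) for cytotoxicity, read by MTT assay (on this read-out lower numbers stand for higher toxicity in this test and higher numbers for lower toxicity in this test), and stands level with the other two measured members of the series. Compound 2 (`Cc1ccccc1-c1cc(C)c(Oc2cc(N)nc(Nc3ccc(C#N)cc3)n2)c(C)c1`) gives 25600 nM on the same read-out, and compound 1 (`Cc1cc(-c2ccc(Cl)cc2)cc(C)c1Oc1cc(N)nc(Nc2ccc(C#N)cc2)n1`) gives 21500 nM there. All three numbers lie within the scatter of one another, so no order can be read from them.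

Compound 4 (`Cc1ccc(-c2cc(C)c(Oc3cc(N)nc(Nc4ccc(C#N)cc4)n3)c(C)c2)cc1`) differs from compound 3 by one change, 4-methylphenyl in place of 3-methylphenyl on an aromatic carbon and nothing else.

For the measured compounds named here, replacing 2-methylphenyl by 3-methylphenyl gave a 1.1-fold higher number from compound 2 to compound 3 (0.03 log units; within the scatter) and is the closest precedent. Replacing 4-chlorophenyl gave a 1.2-fold higher number from compound 1 to compound 2 (0.08 log units; within the scatter) with 2-methylphenyl and a 1.3-fold higher number from compound 1 to compound 3 (0.11 log units; within the scatter) with 3-methylphenyl as the incoming group.

Resting on compound 3 at 27600 nM and on these small steps, no step beyond the scatter is expected in this assay and no direction is favoured. The estimated change is a 1.1-fold lower number from compound 3 to compound 4 (0.03 log units; within the scatter) and is expected to stay within the scatter. The value expected for compound 4 is 26000 nM (estimated range 16000 nM to 40000 nM).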

Compound 4, half-maximal cytotoxic concentration: 10000 nM
Estimate against measurement, compound 4: 2.6-fold (0.41 log units) above; measured number below the stated range.
By their numbers in this assay, from the lowest: compound 4; then compounds 1, 2 and 3 (each within the scatter of the next).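

In this assay, for the compounds shown here, 4-methylphenyl in place of 3-methylphenyl keeps the same atoms and only joins them differently, yet it gives a 2.8-fold lower number from compound 3 to compound 4 (0.44 log units; beyond the scatter), the first step beyond the scatter and a shift towards higher toxicity in this test. The other two steps point the same way, with a 2.6-fold lower number from compound 2 to compound 4 (0.41 log units; beyond the scatter) for 4-methylphenyl in place of 2-methylphenyl and a 2.2-fold lower number from compound 1 to compound 4 (0.33 log units; beyond the scatter) for methyl in place of chloro, so the number at this position is sensitive both to where the methyl sits on the incoming ring and to what occupies its 4-position, since 4-chlorophenyl stays within the scatter of 2-methylphenyl and 3-methylphenyl. Nothing available bears on the reason for this shift.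

As far as these compounds go, the steps are modest and rest on a single member, so it remains open whether the lower number is particular to 4-methylphenyl or extends to other groups at that position. A 4-ethylphenyl, a 4-methoxyphenyl or a 4-aminophenyl group would show whether a longer chain, an ether oxygen or an amine at the same place follows compound 4 or compound 1.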